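The source may report more compounds than this note shows. Statements on the series, on what has been measured and on what is new or still open speak of the compounds shown alone.

In an ADME assay on HepG2 cells (Homo sapiens) for cytotoxicity, read by CellTiter-Glo and resazurin assay, with a stated time of 72 h (a lower number here means that less compound is needed, a higher number that more compound is needed for the effect), compound 2 `CCOC(=O)CCCCCOc1cccc(CN(C(=O)c2ccc(-c3cccc(C(C)=O)c3)cc2)C(C)C)c1` stands only at a limit: it gives > 26000 nM, which is a limit of the assay rather than a number. Its neighbours sit in the same place. Compound 1 `CC(=O)c1cccc(-c2ccc(C(=O)N(Cc3cccc(OCCCCCC(=O)O)c3)C(C)C)cc2)c1` gives > 26000 nM, likewise a limit. Compound 3 `CCOC(=O)CCCCCOc1cccc(CN(C(=O)c2ccc(-c3cccc(Oc4ccccc4)c3)cc2)C(C)C)c1` gives > 26000 nM, also a limit. The step that the two limits leave unreadable from compound 1 to compound 2, which carries ethyl in place of hydrogen on an oxygen next to a carbonyl group, therefore cannot be read, and the same holds for a step that the two limits leave unreadable from compound 2 to compound 3, where phenoxy replaces acetyl on an aromatic carbon; because of the limit of > 26000 nM in this assay, at which 3 of the 3 values shown sit, neither step tells anything about the size of a change. The compound not yet measured, compound 4 `CCOC(=O)CCCCCOc1cccc(CN(C(=O)c2ccc(-c3ccc4c(c3)OCCO4)cc2)C(C)C)c1`, differs from compound 2 by 2,3-dihydro-1,4-benzodioxin-6-yl in place of 3-acetylphenyl on an aromatic carbon. Among the measured compounds shown here, none of the measured steps bears on this exchange in a readable way, and all three measured values sit at a limit, so the expectation for compound 4 is that it will again sit at or near that limit, with an expected step that the limit leaves unreadable from compound 2 to compound 4 that is none beyond the scatter. Compound 4 is therefore estimated at 30000 nM in this assay, with a range from 15000 nM to 60000 nM.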

Compound 4, half-maximal effective concentration: > 24400 nM
Compound 4 was reported as a limit; the forecaster's own chance of this, stated with the estimate: 85%; the middle value is on the limit's open side.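

In this assay compound 4 gives > 24400 nM, which is a limit of the assay and not a number. Among the compounds shown here, compound 2 also stands only at a limit, and no step between compound 2 and compound 4 can be read. The compounds shown leave open at what concentration any of them reaches the half-maximal effect, and whether their exchanges alter it.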